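Swapping Isopropyl for Pentyl: What Might Happen to Tolerance?

A few compounds are considered here, and "the series" means these few. Any claim that something is new, unique, unknown or untested is made for them only; others in the source may bear on it.

In an ADME assay on MT4 cells (Homo sapiens) for cytotoxicity, read by MTT assay (a lower number here means that less compound is tolerated, a higher number that more compound is tolerated), compound 1 (`CC(C)C1C(=O)N(O)C(=O)c2ccccc21`) gives 123000 nM as its reading. Going by the values given here, this is the higher of the two numbers measured so far. The other comes from compound 2 (`O=C1c2ccccc2C(Cc2ccc(C(F)(F)F)cc2)C(=O)N1O`), which gives 6000 nM in this assay as its reading, a gap from compound 1 that lies beyond the usual scatter of repeated measurements.

The next compound to be tested is compound 3 (`CCCCCC1C(=O)N(O)C(=O)c2ccccc21`). It has pentyl in place of isopropyl on a saturated ring carbon. Among the compounds with values here, no measured pair shows this swap directly, so the expectation rests on thin evidence. Compared with compound 1, compound 2 carries a larger group and reads 6000 nM in this assay, which hints that a longer chain might also lower the number, probably by less. Two compounds cannot establish a trend, however. The expected change is a moderate fall, estimated as a 3.1-fold lower number from compound 1 to compound 3 (0.49 log units; beyond the scatter) and so a little beyond the scatter. For compound 3 the estimated value is 40000 nM, with a likely range from 12000 nM to 120000 nM in this assay once it is measured.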

Compound 3, half-maximal cytotoxic concentration: 98300 nM
For compound 3 the middle estimate is 2.5-fold (0.39 log units) below the measured one; the range from low to high includes it.
By their numbers in this assay, from the lowest: compound 2; then compounds 3 and 1 (each within the scatter of the next).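

At this saturated ring carbon, putting pentyl in place of isopropyl gives a 1.3-fold lower number from compound 1 to compound 3 (0.10 log units; within the scatter), so in this assay the two compounds cannot be told apart. Going by these compounds alone, this is the first direct comparison at this position, and it shows that going from a group of 3 carbon atoms to one of 5, neither with a ring nor with any hydrogen-bond donor or acceptor, leaves the reading where it was, whereas compound 2 stands far lower at 6000 nM. Nothing available here explains why the chain swap leaves the reading unmoved.

From the compounds shown here alone, whether an octyl chain, or a chain ending in an amine or a carboxylic acid, would keep the reading at this level remains open, since a single swap says little about how far this tolerance extends. Going by these compounds, it is also open which part of the group in compound 2 goes with its low reading, and a plain benzyl group without the trifluoromethyl would help to separate the contribution of the ring from that of the fluorinated substituent.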